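The compounds below may be only part of what the source reports. "The series", "measured", "known", "first", "only" and "open" are said of these compounds alone.

Compound 3, `COc1ccc(CNc2ncnc3c2ncn3[C@@H]2O[C@H](CO)[C@@H](O)[C@H]2O)c(OC)c1`, has no single number in a functional assay on G-361 cells (Homo sapiens) for antiproliferative activity, with a stated time of 72 h; on this read-out higher numbers stand for weaker inhibition and lower numbers for stronger inhibition: for compound 3 the entry reads "not determined" (no result reported). Compound 2, `Cc1ccc(CNc2ncnc3c2ncn3[C@@H]2O[C@H](CO)[C@@H](O)[C@H]2O)cc1`, likewise shows "not determined" (no result reported) in this assay. Compound 1, `OC[C@H]1O[C@@H](n2cnc3c(NCc4cccc(F)c4)ncnc32)[C@H](O)[C@@H]1O`, reaches only a limit of the assay, given for compound 1 as > 166000 nM. So among the three values shown, one sits at the limit of > 166000 nM in this assay, at which 1 of the 3 values shown sits, and two carry no number at all. Compound 4, `OC[C@H]1O[C@@H](n2cnc3c(NCc4cc(O)cc(O)c4)ncnc32)[C@H](O)[C@@H]1O`, differs from compound 3 by 3,5-dihydroxyphenyl in place of 2,4-dimethoxyphenyl on a saturated chain carbon bound to a nitrogen on an aromatic ring. Going by the values given here, with no measured step in this assay to lean on, and with the one numeric entry, that of compound 1, being a limit, the expectation for compound 4 rests on little. Compound 4 is therefore estimated at 100000 nM in this assay, with a range from 20000 nM to 200000 nM, and a limit rather than a number is expected to be the more likely outcome.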

Compound 4, half-maximal inhibitory concentration: > 166000 nM
Compound 4 was reported as a limit; the forecaster's own chance of this, stated with the estimate: 60%; at least 1.6-fold (0.22 log units) between middle value and limit.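

Compound 1 and compound 4 both stop at a limit of the assay, so no step can be read between them: the limit of > 166000 nM in this assay, at which 2 of the 4 values shown sit. The compounds shown leave open which group, if any, would give a single number in this assay.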